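The source may report more compounds than this note shows. Statements on the series, on what has been measured and on what is new or still open speak of the compounds shown alone.

Working notes on the series. Two compounds share the core that is seen in compound 1 `Cc1cc(C)cc(N2CCNC(=O)N2)c1` and compound 2 `CCc1cccc(N2CCNC(=O)N2)c1`, an aromatic ring carrying a cyclic urea. In an assay on RBL-1 cells for inhibition of Polyunsaturated fatty acid 5-lipoxygenase (Rattus norvegicus) (on this read-out lower numbers stand for stronger inhibition and higher numbers for weaker inhibition), compound 1 gives 12000 nM. In this assay compound 2 gives 13000 nM; the two numbers lie within the scatter of each other, so neither compound can be set apart from the other on these data.

Compound 3 `O=C1NCCN(c2cccc(F)c2)N1` is not yet measured. Relative to compound 2 the change is fluoro in place of ethyl on an aromatic carbon. Among the compounds with values here, no measured step of this kind exists, so the step from compound 2 to compound 3 in this assay is expected to be none beyond the scatter, with no direction favoured; the estimate means a step of a 1.2-fold higher number from compound 2 to compound 3 (0.06 log units; within the scatter). For compound 3 in this assay the estimate is 15000 nM, with a range from 6000 nM to 40000 nM.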

Compound 3, half-maximal inhibitory concentration: 19000 nM
Beside the measured number, compound 3's estimate is 1.3-fold (0.10 log units) below it; low and high end bracket the measured number.
By their numbers in this assay, from the lowest: compounds 1, 2 and 3 (each within the scatter of the next).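

In this assay, fluoro in place of ethyl on this aromatic carbon, meta to a group of 7 heavy atoms, gives a 1.5-fold higher number from compound 2 to compound 3 (0.16 log units; within the scatter). Within the data shown here, this is the first measured single-place step, and it shows that exchanging a two-carbon group for a single fluorine at this position does not separate the two compounds on this read-out. No measurement is available that bears on this result.

Going by these compounds, it remains open whether an amine, a carboxylic acid or a longer chain on this aromatic carbon would give a step beyond the scatter in this assay. The compounds shown also leave open how far a change to the cyclic urea of the shared core would affect the read-out.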